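Sulfanyl to sulfonyl on the shared core: working notes

This account rests on a few compounds, and the source may have more. Where it says the series, first, only, none or still open, it means among the compounds named here.

Measured so far:
compound 1 `CCCSc1nnc(COc2cc(C)c3c(C)cc(=O)oc3c2)o1` — > 100000 nM
compound 2 `CCCCSc1nnc(COc2cc(C)c3c(C)cc(=O)oc3c2)o1` — > 100000 nM

In a functional assay on MDA-MB-231 cells (Homo sapiens) for antiproliferative activity, read by MTT assay, with a stated time of 24 h (on this read-out higher numbers stand for weaker inhibition and lower numbers for stronger inhibition), compound 1 gives > 100000 nM, which is a limit of the assay and not a number. Compound 2 likewise gives > 100000 nM in this assay, again a limit. For the measured compounds named here, compound 1 therefore stands only at a limit, and the one step measured around it, a step that the two limits leave unreadable from compound 1 to compound 2, cannot be read for size. Going by the values given here, the only evidence on the measured values is the limit of > 100000 nM in this assay, at which 2 of the 2 values shown sit.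

Compound 3 `CCS(=O)(=O)c1nnc(COc2cc(C)c3c(C)cc(=O)oc3c2)o1` differs from compound 1 by ethylsulfonyl in place of propylsulfanyl on an aromatic carbon. Among the compounds with values here, no measured step bears on this change: the single step in the set concerns a methyl on the chain and is itself unreadable. Nothing in the data points to a step in either direction beyond the scatter, so the expectation rests on compound 1 sitting at > 100000 nM and on (the limit of > 100000 nM in this assay, at which 2 of the 2 values shown sit).

Compound 3 is expected to give 100000 nM in this assay, within 30000 nM to 300000 nM. The expected step is a number no higher from compound 1 to compound 3 (the limit leaves the size open), and a limit rather than a number remains the likelier outcome.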

Compound 3, half-maximal inhibitory concentration: > 100000 nM
Compound 3 ended at the assay's limit; the forecaster's own chance of this, stated with the estimate: 80%; the middle value lies on the limit itself.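

In this assay compound 3 gives > 100000 nM, a limit of the assay and not a number. The steps from compound 1 and from compound 2 to compound 3 therefore cannot be read for size. The compounds shown leave open whether any change on the shared core gives a readable value at all: the limit of > 100000 nM in this assay, at which 3 of the 3 values shown sit.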